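The compounds below may be only part of what the source reports. "The series", "measured", "known", "first", "only" and "open" are said of these compounds alone.

Of the compounds shown here, three sharing one core have been measured in an ADME assay on MT4 cells (Homo sapiens) for cytotoxicity, read by MTT assay, with a stated time of 96 h; on this read-out lower numbers stand for higher toxicity in this test and higher numbers for lower toxicity in this test. Compound 1 `Oc1ccc(-c2nc3cc(C(F)(F)F)ccc3[nH]2)cc1` gives 17000 nM in this assay. Compound 2 `CCN(CC)CC(=O)Nc1ccc(-c2nc3cc(C(F)(F)F)ccc3[nH]2)cc1` gives 8000 nM in this assay, and compound 3 `Fc1ccc(-c2nc3cc(C(F)(F)F)ccc3[nH]2)cc1` gives 22000 nM in this assay. Compound 3 thus holds the highest of the three numbers, though only narrowly over compound 1, since a 1.3-fold higher number from compound 1 to compound 3 (0.11 log units; within the scatter), while a 2.8-fold higher number from compound 2 to compound 3 (0.44 log units; beyond the scatter) and a 2.1-fold lower number from compound 1 to compound 2 (0.33 log units; beyond the scatter).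

The next compound, compound 4 `O=C(CCl)Nc1ccc(-c2nc3cc(C(F)(F)F)ccc3[nH]2)cc1`, has not yet been measured in this assay. The change from compound 3 to compound 4 is ((chloromethyl)carbonyl)amino in place of fluoro on an aromatic carbon. Among the measured compounds shown here, the steps that bear on this are those in which the aromatic carbon carries a hydroxy, a fluoro or a (((diethylamino)methyl)carbonyl)amino group. Of these, a 1.3-fold higher number from compound 1 to compound 3 (0.11 log units; within the scatter) lies within the scatter, whereas a 2.8-fold higher number from compound 2 to compound 3 (0.44 log units; beyond the scatter) and a 2.1-fold lower number from compound 1 to compound 2 (0.33 log units; beyond the scatter) are modest steps beyond it, both pointing the same way, with the (((diethylamino)methyl)carbonyl)amino group giving the lower number. Because a 2.8-fold higher number from compound 2 to compound 3 (0.44 log units; beyond the scatter) and a 2.1-fold lower number from compound 1 to compound 2 (0.33 log units; beyond the scatter) both put the lower number on the side of the (((diethylamino)methyl)carbonyl)amino group, and compound 4 likewise carries a ((chloromethyl)carbonyl)amino group where compound 3 carries fluoro, a modest step down in this assay is expected, a 2.8-fold lower number from compound 3 to compound 4 (0.44 log units; beyond the scatter). Compound 4 is therefore estimated at 8000 nM, with a range from 3000 nM to 20000 nM.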

Compound 4, half-maximal cytotoxic concentration: 5000 nM
Estimate against measurement, compound 4: 1.6-fold (0.20 log units) above, and the stated range covers the measured number.
By their numbers in this assay, from the lowest: compounds 4 and 2 (each within the scatter of the next); then compounds 1 and 3 (each within the scatter of the next).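

A second carbonylamino group on this aromatic carbon now gives a lower number in this assay: ((chloromethyl)carbonyl)amino in place of fluoro produces a modest step beyond the scatter (a 4.4-fold lower number from compound 3 to compound 4 (0.64 log units; beyond the scatter)), and the same group in place of hydroxy does likewise (a 3.4-fold lower number from compound 1 to compound 4 (0.53 log units; beyond the scatter)). Until now, only the (((diethylamino)methyl)carbonyl)amino group had shown this, but among these four compounds, both groups of this type now sit on the lower side, with no compound going against that pattern. Chloro in place of diethylamino on the chain carbon makes no difference that can be told from scatter (a 1.6-fold lower number from compound 2 to compound 4 (0.20 log units; within the scatter)), although nothing measured here explains these numbers.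

The compounds shown leave open whether a plain amino group or an acetylamino group, which has a methyl in place of the chloromethyl, would fall with compounds 2 and 4 or with compounds 1 and 3. They also leave open whether a methoxy group on the same carbon would stay with hydroxy and fluoro.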